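Methoxy to Hydroxy: What Compound 3 Might Show

The source may report more compounds than this note shows. Statements on the series, on what has been measured and on what is new or still open speak of the compounds shown alone.

In a functional assay on A549 cells (Homo sapiens) for antiproliferative activity, read by sulforhodamine B assay, with a stated time of 48 h (on this read-out higher numbers stand for weaker inhibition and lower numbers for stronger inhibition), compound 1 (`COc1ccc(/C=C/C(=O)c2ccccc2-c2ccc(F)cc2)cc1O`) gives 65 nM and compound 2 (`COc1ccc(/C=C/C(=O)c2ccccc2-c2cccc(F)c2)cc1OC`) gives 330 nM as the higher of the two numbers, a gap beyond the usual scatter. Compound 3 (`COc1ccc(/C=C/C(=O)c2ccccc2-c2cccc(F)c2)cc1O`) differs from compound 2 by one change, methoxy to hydroxy (hydrogen in place of methyl on an oxygen on an aromatic ring), with hydrogen in place of methyl on an oxygen on an aromatic ring. Going by the values given here, no measured pair shows this change alone. Compound 1 also carries a hydroxy and stands at 65 nM in this assay although it differs elsewhere too, so a clear drop in the number is expected, meaning stronger inhibition. The expected step is (a 3.7-fold lower number from compound 2 to compound 3 (0.56 log units; beyond the scatter)). The estimate for compound 3 is (90 nM), with an expected range of 25 nM to (300 nM).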

Compound 3, half-maximal inhibitory concentration: 11 nM
Beside the measured number, compound 3's estimate is 8.2-fold (0.91 log units) above it; the whole stated range lies above it.
By their numbers in this assay, from the lowest: compound 3; then compound 1; then compound 2.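

In this assay, the change from methoxy to hydroxy, taken alone, gives a 30-fold lower number from compound 2 to compound 3 (1.48 log units; beyond the scatter) and so shows that this single methyl on an oxygen matters greatly here. The fluorine's place also counts, but less: 3-fluorophenyl in place of 4-fluorophenyl gives a 5.9-fold lower number from compound 1 to compound 3 (0.77 log units; beyond the scatter) in the same assay. Nothing available explains either step.

Still open, as far as these compounds go, is whether the hydroxy step would be as large with 4-fluorophenyl on the core. Also open, from the compounds shown here alone, is how an amine or a longer chain such as ethoxy would compare in place of the hydroxy.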